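A few compounds are considered here, and "the series" means these few. Any claim that something is new, unique, unknown or untested is made for them only; others in the source may bear on it.

Measured in an ADME assay (liver) for metabolic stability, with Liver microsome (Rattus norvegicus) as the target, using microsomes and NADPH, with a stated time of 30 min, at 37 degrees C, tested at 1 uM; a higher number here means faster removal of the compound, a lower number slower removal:
- Compound 1 `Nc1ccc(S(=O)(=O)c2ccc(-c3ncc(C(O)(C(F)(F)F)C(F)(F)F)cc3C#CCO)cc2)cn1`: 36 mL.min-1.g-1
- Compound 2 `CC(O)(c1ccc(-c2ncc(S(=O)(=O)c3ccc(N)nc3)s2)c(Cl)c1)C(F)(F)F`: < 14 mL.min-1.g-1

Compound 2 gives only a limit and not a number: it stands at the limit of < 14 mL.min-1.g-1 in this assay, at which 1 of the 2 values shown sits. Compound 3 `CC(C)(O)c1ccc(-c2ncc(S(=O)(=O)c3ccc(N)nc3)s2)c(Cl)c1` has not yet been measured. It differs from compound 2 in one place, with 1-hydroxy-1-methylethyl in place of 1-hydroxy-1-(trifluoromethyl)ethyl: methyl in place of trifluoromethyl on a saturated chain carbon bound to an aromatic carbon, an oxygen on a saturated carbon and a saturated chain carbon. Going by the values given here, no measured pair of compounds shows this change. A modest rise in this assay is expected, with the step estimated as an at least 1.4-fold higher number from compound 2 to compound 3 (0.15 log units; that floor lies within the scatter). Compound 3 is expected to give 20 mL.min-1.g-1, within an estimated range of 10 mL.min-1.g-1 to 42 mL.min-1.g-1.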

Compound 3, intrinsic clearance in microsomes: 17 mL.min-1.g-1
Estimate against measurement, compound 3: 1.2-fold (0.07 log units) above, within the range that was stated.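

Going by these compounds alone, this is the first pair of compounds to show methyl in place of trifluoromethyl on this saturated chain carbon, and in this assay the change gives an at least 1.2-fold higher number from compound 2 to compound 3 (0.08 log units; that floor lies within the scatter) as its only readable size. A larger step is not ruled out, and the true size stays unknown because compound 2 gives a limit and not a number: the limit of < 14 mL.min-1.g-1 in this assay, at which 1 of the 3 values shown sits.

As far as these compounds go, whether ethyl, cyclopropyl or a plain hydrogen on this same carbon would move the number further remains open. So does whether an amine in place of the hydroxy group would change it.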